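Aryl Change at the Ring Nitrogen: Expectation for Compound 3

The source may hold more compounds than are shown below. What is called first, only, known or untested is meant among the compounds shown, and "the series" means these compounds.

The measurements to hand, all in a functional assay on HT-29 cells (Homo sapiens) for cytotoxicity, read by MTT assay, with a stated time of 72 h; a higher number here means a weaker inhibitor, a lower number a stronger inhibitor:
compound 1, `COc1cc2c(Oc3ccc(NC(=O)c4nnn(-c5ccc(F)cc5)c4C(F)(F)F)cc3F)ccnc2cc1OCCCN1CCCC1`, gives 120 nM
compound 2, `COc1cc2c(Oc3ccc(NC(=O)c4nnn(-c5ccc(F)cc5)c4C(F)(F)F)cc3F)ccnc2cc1OCCCN1CCC(C)CC1`, gives 160 nM

Going by the values given here, of these two numbers compound 2 holds the higher one, but the only measured step, a 1.3-fold higher number from compound 1 to compound 2 (0.12 log units; within the scatter), stays within the scatter, so the two compounds cannot be placed in any order on this evidence. Compound 3, `COc1cc2c(Oc3ccc(NC(=O)c4nnn(-c5cccc(Br)c5)c4C(F)(F)F)cc3F)ccnc2cc1OCCCN1CCC(C)CC1`, is built from compound 2 by one change: 3-bromophenyl in place of 4-fluorophenyl on an aromatic nitrogen.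

Among the compounds with values here, no measured step touches this part of the molecule. Within the data shown here, the one step available concerns the saturated chain on the other side of the shared core, and it tells nothing about an exchange of the aryl group on the ring nitrogen. Among the measured compounds shown here, with no bearing step, and the only measured step lying within the scatter, the expectation is a step of no more than the usual scatter, in no firm direction, a 1.3-fold higher number from compound 2 to compound 3 (0.10 log units; within the scatter), but with a wide allowance for the unknown.

Compound 3 is therefore expected to give about 200 nM in this assay, within a range from 60 nM to 700 nM.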

Compound 3, half-maximal inhibitory concentration: 380 nM
Beside the measured number, compound 3's estimate is 1.9-fold (0.28 log units) below it; measured number inside the range.
By their numbers in this assay, from the lowest: compounds 1 and 2 (each within the scatter of the next); then compound 3.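

Going by these compounds alone, the exchange of 4-fluorophenyl for 3-bromophenyl on the aromatic nitrogen gives the first step beyond the scatter in this assay (a 2.4-fold higher number from compound 2 to compound 3 (0.38 log units; beyond the scatter)), a modest one in the direction of a weaker inhibitor. Within the data shown here, this shows that the number responds to the aryl group at this place, which the earlier compounds left unchanged, while their only step, in the saturated chain (a 1.3-fold higher number from compound 1 to compound 2 (0.12 log units; within the scatter)), stayed within the scatter. The two aryl groups have the same heavy-atom count and the same counts of hydrogen-bond donors and acceptors, so those counts do not distinguish them, and nothing available bears on why the number rose.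

This single step changes both the halogen and where it stands on the phenyl ring, and a 4-bromophenyl or 3-fluorophenyl group on this nitrogen would be needed to tell those two changes apart. Also open, going by these compounds, are how an unsubstituted phenyl or a pyridyl ring would compare here, and whether the step would hold with the pyrrolidin-1-yl chain of compound 1.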